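This account rests on a few compounds, and the source may have more. Where it says the series, first, only, none or still open, it means among the compounds named here.

The compounds here share one core and differ only in the group on a double-bonded chain carbon bound to a double-bonded chain carbon. All were tested in a functional assay on cells (Neutrophil, Rattus norvegicus) for inhibition; a lower number here means a stronger inhibitor, a higher number a weaker inhibitor. Compound 1 (`COc1ccc(OC)c(C(=O)/C=C/c2ccco2)c1`), which carries furan-2-yl, gives 3000 nM. Compound 2 (`COc1ccc(OC)c(C(=O)/C=C/c2cccs2)c1`), which carries thiophen-2-yl, gives > 30000 nM, a limit of the assay and not a number. Compound 3 (`COc1ccc(OC)c(C(=O)/C=C/c2ccc(C)o2)c1`), which carries 5-methylfuran-2-yl, gives > 30000 nM, also a limit and not a number. Compound 3 therefore has no exact position, and it sits at the limit of > 30000 nM in this assay, at which 2 of the 3 values shown sit.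

Compound 4 (`COc1ccc(OC)c(C(=O)/C=C/c2ccc(C)s2)c1`) makes one change to compound 3: 5-methylthiophen-2-yl in place of 5-methylfuran-2-yl on a double-bonded chain carbon bound to a double-bonded chain carbon.

Among the compounds with values here, two measured steps bear on this change. The first is an at least 10-fold higher number from compound 1 to compound 2 (1.00 log units; beyond the scatter), and the second is an at least 10-fold higher number from compound 1 to compound 3 (1.00 log units; beyond the scatter). Both lie beyond the scatter, and compound 4 carries both the thiophen ring and the methyl. The direct comparison, a step that the two limits leave unreadable from compound 2 to compound 3, gives no usable size.

No recovery of inhibition is therefore expected, and the expected change is a number no higher from compound 3 to compound 4 (the limit leaves the size open). The estimate for compound 4 is 30000 nM, within a range from 10000 nM to 100000 nM, and a limit rather than a number is the likely report.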

Compound 4, half-maximal inhibitory concentration: > 30000 nM
Compound 4 gave a limit, no number; the forecaster's own chance of this, stated with the estimate: 80%; the middle value lies on the limit itself.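

In this assay, the newest change again loses inhibition, with an at least 10-fold higher number from compound 1 to compound 4 (1.00 log units; beyond the scatter). This shows that combining the thiophene ring with the methyl does not bring back the inhibition that each change loses on its own. At this place on the double-bonded chain carbon, furan-2-yl is the only one of the four groups with a measured number, and the other three all stop at the same assay limit: the limit of > 30000 nM in this assay, at which 3 of the 4 values shown sit.

The steps among compound 2, compound 3 and compound 4 cannot be read, and nothing here puts these three groups in order. As far as these compounds go, it remains open whether any other group at this place can match or improve on compound 1, which gives 3000 nM, for example a phenyl ring, a pyridine ring or a furan ring carrying a chlorine atom, an amine or a carboxylic acid in place of the methyl.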